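1,3-Benzoxazol-2-yl for 1,3-benzothiazol-2-yl: an untested exchange

A few compounds are considered here, and "the series" means these few. Any claim that something is new, unique, unknown or untested is made for them only; others in the source may bear on it.

Compound 3, `O=C(Nc1cccc(-c2nc3ccccc3s2)c1)c1cc([N+](=O)[O-])ccc1Cl`, was examined in an ADME assay on HepG2 cells (Homo sapiens) for cytotoxicity, with a stated time of 72 h (on this read-out higher numbers stand for an effect only at larger amounts of compound and lower numbers for an effect already at smaller amounts), where compound 3 gives > 27000 nM, which is a limit of the assay rather than a number. The two other measured compounds stand at limits as well. Compound 1, `Cc1ccc(-c2nc3ccccc3o2)cc1NC(=O)c1cc([N+](=O)[O-])ccc1Cl`, gives in this assay the value > 14000 nM, again a limit. Compound 2, `O=C(Nc1cc(-c2nc3ccccc3o2)ccc1F)c1cc([N+](=O)[O-])ccc1Cl`, gives in this assay the value > 25000 nM, also a limit. Going by the values given here, the only step between measured compounds that differ in a single place, a step that the two limits leave unreadable from compound 1 to compound 2, can therefore not be read. That all three values sit at limits is recorded in the limit of > 14000 nM in this assay, at which 1 of the 3 values shown sits, the limit of > 25000 nM in this assay, at which 1 of the 3 values shown sits, and (the limit of > 27000 nM in this assay, at which 1 of the 3 values shown sits).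

Compound 4, `O=C(Nc1cccc(-c2nc3ccccc3o2)c1)c1cc([N+](=O)[O-])ccc1Cl`, differs from compound 3 by 1,3-benzoxazol-2-yl in place of 1,3-benzothiazol-2-yl on an aromatic carbon. Among the compounds with values here, no measured step concerns this exchange, and the one measured step is unreadable, so the expectation rests only on where compound 3 stands. The step to be expected is a number no higher from compound 3 to compound 4 (the limit leaves the size open), that is, none beyond the scatter. The value of compound 4 in this assay is estimated at 27000 nM, in a range from 10000 nM to 80000 nM, and is most likely reported once more as a limit.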

Compound 4, half-maximal effective concentration: > 25000 nM
Compound 4: only a limit was reported (the forecaster's own chance of this, stated with the estimate: 85%); the middle value lies beyond the limit too.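

In this assay compound 4 gives > 25000 nM, a limit of the assay and not a number. The steps from compound 1, compound 2 and compound 3 to compound 4 therefore cannot be read. The compounds shown leave open where any of the four would reach a half-maximal effect, and whether 1,3-benzoxazol-2-yl in place of 1,3-benzothiazol-2-yl alters it.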